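The source may report more compounds than this note shows. Statements on the series, on what has been measured and on what is new or still open speak of the compounds shown alone.

Working notes on the series. Among the measured compounds shown here, compound 1 `Nc1nc(N)c2c(-c3ccsc3)cn([C@@H]3O[C@H](CO)[C@@H](O)[C@H]3O)c2n1` is the first of three compounds measured in a functional assay on HepG2 cells (Homo sapiens) for antiproliferative activity, read by XTT assay, with a stated time of 72 h; on this read-out higher numbers stand for weaker inhibition and lower numbers for stronger inhibition. Compound 1 gives only a limit, > 20000 nM, in this assay. For the measured compounds named here, compound 2 `C#Cc1cn([C@@H]2O[C@H](CO)[C@@H](O)[C@H]2O)c2ncnc(OC)c12` is the one member that returns a number, and in this assay compound 2 gives 12700 nM. Compound 3 `O=c1[nH]cnc2c1c(-c1cc3ccccc3o1)cn2[C@@H]1O[C@H](CO)[C@@H](O)[C@H]1O` also returns only a limit, > 20000 nM, in this assay. Compound 3 thus stands at the limit shared by two of the three values, as set out in the limit of > 20000 nM in this assay, at which 2 of the 3 values shown sit; only compound 2 sits below that limit, and even that number is far from potent. Compound 4 `O=c1[nH]cnc2c1c(-c1cccs1)cn2[C@@H]1O[C@H](CO)[C@@H](O)[C@H]1O` is the next member to be measured in this assay. It differs from compound 3 by thiophen-2-yl in place of 1-benzofuran-2-yl on an aromatic carbon. Going by the values given here, no measured pair shows the effect of a change of this kind, and the limits of compound 1 and compound 3 give no direction. Compound 4 is therefore expected to stay near the limit, with the step that the limit leaves unreadable from compound 3 to compound 4 estimated as nothing beyond the scatter. The estimate for compound 4 in this assay is 25000 nM, with a range from 8000 nM to 80000 nM.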

Compound 4, half-maximal inhibitory concentration: > 20000 nM
Compound 4 was reported as a limit; the forecaster's own chance of this, stated with the estimate: 70%; the middle value lies beyond the limit too.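

Among the compounds shown here, compound 3 and compound 4 both return only limits in this assay, so no step between them can be read; they sit together at the assay's ceiling: the limit of > 20000 nM in this assay, at which 3 of the 4 values shown sit. The compounds shown leave open whether thiophen-2-yl in place of 1-benzofuran-2-yl changes activity at all.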